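Amide Alkyl Change in a Thiourea Series

This account rests on a few compounds, and the source may have more. Where it says the series, first, only, none or still open, it means among the compounds named here.

Compound 1 `CNC(=O)c1cc(Oc2cccc(NC(=S)Nc3ccc(Cl)cc3Cl)c2)ccn1` gives > 100000 nM in a functional assay on MDA-MB-231 cells (Homo sapiens) for cytotoxicity, read by MTT assay, with a stated time of 48 h (on this read-out higher numbers stand for weaker inhibition and lower numbers for stronger inhibition), and this value is a limit of the assay.
Compound 2 `CNC(=O)c1cc(Oc2cccc(NC(=S)Nc3ccc(Cl)cc3)c2)ccn1` gives > 100000 nM in this assay, which is likewise a limit.

Compound 2 therefore stands at the limit and has no number of its own; both values shown sit at that same limit (the limit of > 100000 nM in this assay, at which 2 of the 2 values shown sit). Within the data shown here, the only measured step, a step that the two limits leave unreadable from compound 1 to compound 2, is one whose size cannot be read, so it gives no scale for any change.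

Compound 3 `CC(C)NC(=O)c1cc(Oc2cccc(NC(=S)Nc3ccc(Cl)cc3)c2)ccn1` differs from compound 2 by isopropyl in place of methyl on an amide-type nitrogen. Among the measured compounds shown here, no measured step touches this place, and the single step that exists is unreadable, so there is no ground to expect a shift beyond the scatter in this assay in either direction. Compound 3 is expected to give 150000 nM, within 30000 nM to 500000 nM. The step this estimate means is a step that the limit leaves unreadable from compound 2 to compound 3, most likely again reported only as a limit.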

Compound 3, half-maximal inhibitory concentration: 87500 nM
The estimate for compound 3 lay 1.7-fold (0.23 log units) above the measured number, and the stated range covers the measured number.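

Compound 3 is the first compound shown to give a real number rather than a limit in this assay, so the amide position can affect this read-out's reportability within the series. Isopropyl in place of methyl on an amide-type nitrogen gives an at least 1.1-fold lower number from compound 2 to compound 3 (0.05 log units; that floor lies within the scatter); that floor lies within the scatter, and the true size of the step stays unknown, as one end of it is only a limit. The new number therefore marks a single readable point, while most of the values shown still sit at one limit: the limit of > 100000 nM in this assay, at which 2 of the 3 values shown sit.

The compounds shown leave open whether a longer chain such as n-butyl, or a ring such as cyclopropyl, on this nitrogen would take the number lower. They also leave open whether isopropyl gives a readable number alongside the second chloro group of compound 1.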